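Anilino substituent swap in a sodium/hydrogen exchanger inhibitor series

This account rests on a few compounds, and the source may have more. Where it says the series, first, only, none or still open, it means among the compounds named here.

Measured compounds:
Compound 1, `Cc1cc(-c2ccc(F)cc2)c(S(C)(=O)=O)cc1C(=O)N=C(N)N`, gives 36 nM.
Compound 2, `Cc1cc(N2CCCC2)c(S(C)(=O)=O)cc1C(=O)N=C(N)N`, gives 11 nM.

Both compounds were tested in a functional assay for inhibition of sodium/hydrogen exchanger (Oryctolagus cuniculus); on this read-out lower numbers stand for stronger inhibition and higher numbers for weaker inhibition. Compound 2 stands at the lowest of the two numbers; its nearest neighbour is compound 1, and the step of a 3.3-fold lower number from compound 1 to compound 2 (0.51 log units; beyond the scatter) lies beyond the scatter. Compound 3, `Cc1cc(Nc2ncccn2)c(S(C)(=O)=O)cc1C(=O)N=C(N)N`, has not been measured yet. It differs from compound 2 in one place: (pyrimidin-2-yl)amino in place of pyrrolidin-1-yl on an aromatic carbon. Among the compounds with values here, only one measured step bears on this change, the exchange of 4-fluorophenyl for pyrrolidin-1-yl that gave a 3.3-fold lower number from compound 1 to compound 2 (0.51 log units; beyond the scatter), which favoured the pyrrolidin-1-yl over an aromatic ring at this carbon. The (pyrimidin-2-yl)amino group again carries an aromatic ring, so compound 3 is expected to move back toward compound 1, with a modest step of a 2.7-fold higher number from compound 2 to compound 3 (0.44 log units; beyond the scatter). For compound 3 the estimate in this assay is 30 nM, with a range from 8 nM to 120 nM.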

Compound 3, half-maximal inhibitory concentration: 8.3 nM
Estimate against measurement, compound 3: 3.6-fold (0.56 log units) above; the measured number falls inside the stated range.
By their numbers in this assay, from the lowest: compounds 3 and 2 (each within the scatter of the next); then compound 1.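

In this assay the exchange of pyrrolidin-1-yl for (pyrimidin-2-yl)amino gave a 1.3-fold lower number from compound 2 to compound 3 (0.12 log units; within the scatter), so this carbon accepts a six-membered aromatic ring with 2 hetero atoms, carried on an amino nitrogen, without any change beyond the scatter. Set against 4-fluorophenyl, the same group gave a 4.3-fold lower number from compound 1 to compound 3 (0.64 log units; beyond the scatter), so the first step cannot be read as a penalty for any aromatic ring here, and compound 3 goes against that reading. No measurement at hand gives a reason for the gap between these two aromatic groups.

The compounds shown leave open whether the amino link or the ring nitrogens separate compound 3 from compound 1, which phenylamino or a directly attached pyrimidin-2-yl would test. They also leave open how a small group such as a simple amine or methoxy would fare at this carbon.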